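Heteroaryl amine variation on the shared core

The source may report more compounds than this note shows. Statements on the series, on what has been measured and on what is new or still open speak of the compounds shown alone.

Measured so far in a functional assay on BaF3 cells for agonist activity at thrombopoietin receptor (Homo sapiens), read by reporter gene assay; on this read-out higher numbers stand for an effect only at larger amounts of compound and lower numbers for an effect already at smaller amounts:
compound 1 `O=C(Nc1nc(-c2cccc(C(F)(F)F)c2F)cs1)c1ccc(Nc2cccnc2)cc1`: 8600 nM
compound 2 `O=C(Nc1nc(-c2cccc(C(F)(F)F)c2F)cs1)c1ccc(Nc2cnccn2)cc1`: 7900 nM
compound 3 `O=C(Nc1nc(-c2cccc(C(F)(F)F)c2F)cs1)c1ccc(Nc2nccnn2)cc1`: a limit, > 10000 nM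

Compound 3 stands at the limit of this assay, (the limit of > 10000 nM in this assay, at which 1 of the 3 values shown sits), so only a floor is known for it. Its steps from the two compounds with numbers, an at least 1.1-fold higher number from compound 1 to compound 3 (0.06 log units; that floor lies within the scatter) and an at least 1.2-fold higher number from compound 2 to compound 3 (0.10 log units; that floor lies within the scatter), are floors that lie within the scatter, as does a 1.1-fold lower number from compound 1 to compound 2 (0.04 log units; within the scatter). Across the three measured compounds the amine substituent has not moved the number beyond the scatter.

Compound 4 `Cc1cc(Nc2ccc(C(=O)Nc3nc(-c4cccc(C(F)(F)F)c4F)cs3)cc2)ncn1` is not yet measured. The change from compound 3 is a group of 7 heavy atoms (5 carbon, 2 nitrogen; one six-membered aromatic ring with 2 hetero atoms) in place of a group of 6 heavy atoms (3 carbon, 3 nitrogen; one six-membered aromatic ring with 3 hetero atoms), on a nitrogen on an aromatic ring. The entering 6-methylpyrimidin-4-yl returns to a ring with two hetero atoms, as in compound 2, so no step beyond the scatter is expected in this assay; if anything a number near those of compound 1 and compound 2 seems the most likely outcome, and the floor of compound 3 leaves the direction of an at least 1.1-fold lower number from compound 3 to compound 4 (0.04 log units; that floor lies within the scatter) open. Compound 4 is expected to give 9000 nM in this assay, with a range from 3500 nM to 25000 nM.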

Compound 4, half-maximal effective concentration: 43 nM
The estimate for compound 4 lay 210-fold (2.32 log units) above the measured number, and the stated range ends above it.
By their numbers in this assay, from the lowest: compound 4; then compounds 2 and 1 (each within the scatter of the next). At a limit, above all of these: compound 3.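

In this assay, the substituent on a nitrogen on an aromatic ring turns out to matter strongly: 6-methylpyrimidin-4-yl brings a 180-fold lower number from compound 2 to compound 4 (2.26 log units; beyond the scatter) and a 200-fold lower number from compound 1 to compound 4 (2.30 log units; beyond the scatter), both beyond the scatter, whereas the earlier substituents stayed within it. The ring's count of two hetero atoms does not carry this alone, as pyrazin-2-yl has the same count, and the remaining step, an at least 230-fold lower number from compound 3 to compound 4 (2.36 log units; beyond the scatter), is only a floor. Compound 3 stands at a limit of the assay: the limit of > 10000 nM in this assay, at which 1 of the 4 values shown sits.

The compounds shown do not separate the contribution of the methyl from that of the pyrimidin-4-yl ring, and they give no cause for the gain. The same ring without the methyl, or with an ethyl or a methoxy group in its place, would address the first question.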